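This account rests on a few compounds, and the source may have more. Where it says the series, first, only, none or still open, it means among the compounds named here.

In a physicochemical assay for solubility, in phosphate buffer (a higher number here means a more soluble compound, a lower number a less soluble compound), compound 1 `Cc1cc(N[C@H](CCCCNCc2ccccc2F)C(=O)NO)cc(C)c1F` gives > 5 ug/mL, which is a limit of the assay and not a number. Compound 2 `Cc1cc(N[C@H](CCCCNCc2ccc(C(F)(F)F)cc2)C(=O)NO)cc(C)c1F` gives > 5 ug/mL, and this too is a limit rather than a number. Compound 2 therefore has no exact place on the scale. Within the data shown here, the only measured change in this small set is a step that the two limits leave unreadable from compound 1 to compound 2, so it offers no size to carry forward.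

Compound 3 `Cc1cc(N[C@H](CCCCNCc2ccc([N+](=O)[O-])cc2)C(=O)NO)cc(C)c1F` differs from compound 2 in one place: nitro in place of trifluoromethyl on an aromatic carbon. Among the measured compounds shown here, no measured step involves this exchange, and the step between compound 1 and compound 2 is the only neighbouring evidence. It gives neither a direction nor a size, so no step beyond the usual scatter is expected in this assay, due to the limit of > 5 ug/mL in this assay, at which 2 of the 2 values shown sit.

The expected step is a step that the limit leaves unreadable from compound 2 to compound 3. For compound 3 the estimated solubility is 8 ug/mL, with an expected range from 4 ug/mL to 25 ug/mL.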

Compound 3, solubility: > 5 ug/mL
Compound 3: no number, only a limit; the forecaster's own chance of this, stated with the estimate: 80%; the middle value is on the limit's open side.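

In this assay compound 3 gives > 5 ug/mL, which is again a limit of the assay and not a number. The steps among compound 1, compound 2 and compound 3 therefore cannot be read, due to this shared limit: the limit of > 5 ug/mL in this assay, at which 3 of the 3 values shown sit.

As far as these compounds go, the exact solubility of each of the three compounds stays open, as does whether exchanging 2-fluorophenyl, 4-(trifluoromethyl)phenyl and 4-nitrophenyl changes it.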